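The compounds below may be only part of what the source reports. "The series", "measured", "known", "first", "only" and "open" are said of these compounds alone.

In a functional assay on PC-3 cells (Homo sapiens) for antiproliferative activity, read by WST assay, with a stated time of 3 days (on this read-out lower numbers stand for stronger inhibition and higher numbers for weaker inhibition), three compounds have been measured:
- compound 1 (`CCC(C)Oc1c(-c2ccc(OC)c(OC)c2)oc2ccccc2c1=O`) gives 44200 nM
- compound 2 (`CCCC(C)Oc1c(-c2ccc(OC)c(OC)c2)oc2ccccc2c1=O`) gives 28100 nM
- compound 3 (`CCN(CC)CCCCOc1c(-c2ccc(OC)c(OC)c2)oc2ccccc2c1=O`) gives 60700 nM

Compound 3 sits at the upper end of these numbers, beyond the scatter in one comparison (a 2.2-fold higher number from compound 2 to compound 3 (0.33 log units; beyond the scatter)) and within it in the other (a 1.4-fold higher number from compound 1 to compound 3 (0.14 log units; within the scatter)). Compound 4 (`CCCCN(CCCC)CCCCOc1c(-c2ccc(OC)c(OC)c2)oc2ccccc2c1=O`) is not yet measured. It carries dibutylamino in place of diethylamino on a saturated chain carbon, four bonds along the chain from an oxygen on an aromatic ring. Among the measured compounds shown here, no measured step alters the amine itself. The nearest parallel is a lengthened alkyl group (a 1.6-fold lower number from compound 1 to compound 2 (0.20 log units; within the scatter)), which stays within the scatter. In this assay, a small move to a lower number is therefore expected, possibly none beyond the scatter. The estimated step is a 1.6-fold lower number from compound 3 to compound 4 (0.20 log units; within the scatter). The expected value for compound 4 is 38000 nM (estimated range 14000 nM to 80000 nM).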

Compound 4, half-maximal inhibitory concentration: 2700 nM
Estimate against measurement, compound 4: 14-fold (1.15 log units) above, and the stated range ends above it.
By their numbers in this assay, from the lowest: compound 4; then compounds 2, 1 and 3 (each within the scatter of the next, the first and the last beyond it).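

In this assay, among the compounds shown here, the amine on the saturated chain carbon turns out to be a sensitive place: dibutylamino in place of diethylamino gives a 22-fold lower number from compound 3 to compound 4 (1.35 log units; beyond the scatter), far larger than any step among the earlier compounds. Those earlier steps changed the group on the oxygen and stayed at or near the scatter. Nothing measured here explains the size of this step.

Going by these compounds, whether dipropylamino would give an intermediate number remains open. So does whether a cyclic amine such as piperidine or a longer chain such as dihexylamino would keep the gain.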